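The source may hold more compounds than are shown below. What is called first, only, known or untested is meant among the compounds shown, and "the series" means these compounds.

The measured compounds are:
compound 1 `COc1ccc(Cl)cc1C(=O)Nc1ccc(C2=NN(c3ccccc3)C(c3ccc([N+](=O)[O-])cc3)C2)cc1`, which in a functional assay on the whole organism (strain albino) with Rattus norvegicus as the target, read by paw edema, with stated times of 1 h and 4 h, at a dose of 25 mg/kg by the oral route (on this read-out lower numbers stand for a weaker effect and higher numbers for a stronger effect at the one dose given), gives 90.9%;
compound 2 `COc1ccc(C2CC(c3ccc(NC(=O)c4cc(Cl)ccc4OC)cc3)=NN2)cc1`, which in this assay gives 82.6%.

Compound 2 stands as the lower of the two numbers, with compound 1 the nearest to it, and the gap between them lies within the scatter of repeated measurements, so the two compounds cannot be told apart on this read-out. The unmeasured compound 3 `COc1ccc(Cl)cc1C(=O)Nc1ccc(C2=NNC(c3ccc([N+](=O)[O-])cc3)C2)cc1` follows from compound 2 by one change: nitro in place of methoxy on an aromatic carbon. For the measured compounds named here, no step between measured compounds is available to size this change. Compound 2 already shows a strong effect in this assay, and a marked change in either direction is not expected. Compound 3 is therefore estimated to give about 86%, between 74% and 95%, a step of a number 3.4 percentage points higher from compound 2 to compound 3 (within the scatter) that is expected to stay within the scatter.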

Compound 3, a percentage reported as activity, at one dose (the size of the read-out at that dose, not a potency): 91.3%
Compound 3: the middle estimate sits 5.3 percentage points below what was measured; the measured number falls inside the stated range.
By their numbers in this assay, from the lowest: compounds 2, 1 and 3 (each within the scatter of the next).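

In this assay the change from 4-methoxyphenyl to 4-nitrophenyl can now be sized: nitro in place of methoxy, on an aromatic carbon para to a large group, gives a number 8.7 percentage points higher from compound 2 to compound 3 (within the scatter) and so cannot be told from the scatter. A second position also becomes readable, since hydrogen in place of phenyl on the amine nitrogen in the ring gives a number 0.4 percentage points higher from compound 1 to compound 3 (within the scatter) and is equally indistinguishable from the scatter. Nothing available explains either step.

As far as these compounds go, it remains open whether an amine or a carboxylic acid on that aromatic carbon, or a longer chain on the ring nitrogen, would move the read-out beyond the scatter. From the compounds shown here alone, with every value taken at one dose, any difference in potency among the three compounds also remains open.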